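A ring swap on compound 1

The source may report more compounds than this note shows. Statements on the series, on what has been measured and on what is new or still open speak of the compounds shown alone.

For the measured compounds named here, in a functional assay on the whole organism for antagonist activity, with Rattus norvegicus as the target (a lower number here means that less compound is needed, a higher number that more compound is needed for the effect), compound 1 `c1ccc2c(c1)CCC2CCN1CCN(c2cccc3c2OCCO3)CC1` gives 1.29 mg/kg, the higher of the two numbers so far. Compound 2 `c1ccc2c(c1)CC(CCCN1CCN(c3cccc4c3OCCO4)CC1)C2` gives 0.47 mg/kg, but it is no single-change neighbour of compound 1. Compound 3 `Clc1cccc2c1CC2CCN1CCN(c2cccc3c2OCCO3)CC1` replaces the 2,3-dihydro-1H-inden-1-yl group, on a saturated chain carbon, two bonds along the chain from an amine nitrogen in a ring: a group of 9 heavy atoms (8 carbon, 1 chlorine; one four-membered non-aromatic ring of carbon only, one six-membered aromatic ring of carbon only) in place of a group of 9 heavy atoms (9 carbon; one five-membered non-aromatic ring of carbon only, one six-membered aromatic ring of carbon only), on a saturated chain carbon, two bonds along the chain from an amine nitrogen in a ring. Going by the values given here, no measured pair shows this kind of swap, so no step beyond the scatter is expected in this assay. The expected change is a 1.3-fold lower number from compound 1 to compound 3 (0.11 log units; within the scatter). Compound 3 is estimated at 1 mg/kg, with an expected range of 0.3 mg/kg to 3.2 mg/kg.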

Compound 3, dose for 50% inhibition: 1.13 mg/kg
The estimate for compound 3 lay 1.1-fold (0.05 log units) below the measured number; measured number inside the range.
By their numbers in this assay, from the lowest: compound 2; then compounds 3 and 1 (each within the scatter of the next).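

For the compounds shown here, compound 1 and compound 3 form the first single-change pair here, giving a first reading of this saturated chain carbon, two bonds along the chain from an amine nitrogen in a ring. In this assay, replacing 2,3-dihydro-1H-inden-1-yl with the chlorine-bearing group containing a four-membered carbon ring gives a 1.1-fold lower number from compound 1 to compound 3 (0.06 log units; within the scatter), so the two compounds cannot be told apart. No measurement shown explains this result.

From the compounds shown here alone, the chlorine and the four-membered ring enter together, so their separate contributions remain unknown. Going by these compounds, how a methoxy group in place of the chlorine would read also remains open.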